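A Hydroxymethyl for Methoxycarbonyl in a Cytotoxicity Test

A few compounds are considered here, and "the series" means these few. Any claim that something is new, unique, unknown or untested is made for them only; others in the source may bear on it.

In an ADME assay on TZM cells (Homo sapiens) for cytotoxicity, read by XTT assay, with a stated time of 4 days (on this read-out higher numbers stand for lower toxicity in this test and lower numbers for higher toxicity in this test), compound 1 (`Cc1cc(CO)cc(C)c1Oc1cc(Nc2ccc(C#N)cc2)c(N)cc1CO`) gives 15900 nM. Compound 2 (`Cc1cc(CCC#N)cc(C)c1Oc1cc(Nc2ccc(C#N)cc2)c(N)cc1CO`) gives only a limit, > 23800 nM. Compound 3 (`COC(=O)c1cc(N)c(Nc2ccc(C#N)cc2)cc1Oc1c(C)cc(/C=C/C#N)cc1C`) also gives only a limit, > 22800 nM.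

Compound 4 (`Cc1cc(/C=C/C#N)cc(C)c1Oc1cc(Nc2ccc(C#N)cc2)c(N)cc1CO`) differs from compound 3 by hydroxymethyl in place of methoxycarbonyl on an aromatic carbon. Among the compounds with values here, no measured step shows this exact change. The nearest evidence is an at least 1.4-fold higher number from compound 1 to compound 2 (0.17 log units; that floor lies within the scatter), a change elsewhere in two molecules that already carry hydroxymethyl, and it gives no step beyond the scatter. In this assay, no step beyond the scatter is therefore expected, and the estimate is an at least 1.0-fold lower number from compound 3 to compound 4 (0.03 log units; that floor lies within the scatter). For compound 4 the expected value is 21000 nM, with an estimated range of 10000 nM to 42000 nM.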

Compound 4, half-maximal cytotoxic concentration: 16300 nM
The estimate for compound 4 lay 1.3-fold (0.11 log units) above the measured number; low and high end bracket the measured number.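

Hydroxymethyl in place of methoxycarbonyl on this aromatic carbon gives an at least 1.3-fold lower number from compound 3 to compound 4 (0.14 log units; that floor lies within the scatter) in this assay, the first direct reading of this change. At the other changed place, 2-cyanoethenyl in place of 2-cyanoethyl gives an at least 1.4-fold lower number from compound 2 to compound 4 (0.16 log units; that floor lies within the scatter), and 2-cyanoethenyl in place of hydroxymethyl gives a 1.0-fold higher number from compound 1 to compound 4 (0.01 log units; within the scatter). The true size of the step for the methoxycarbonyl change stays unknown because compound 3 gives only a limit: the limit of > 22800 nM in this assay, at which 1 of the 4 values shown sits.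

From the compounds shown here alone, whether a carboxylic acid or an amine on this aromatic carbon would give a step beyond the scatter remains open. The same holds for a longer chain in place of 2-cyanoethenyl.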